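The source may report more compounds than this note shows. Statements on the series, on what has been measured and on what is new or still open speak of the compounds shown alone.

In a functional assay on K562 cells (Homo sapiens), read by MTT assay, with a stated time of 72 h (on this read-out higher numbers stand for weaker inhibition and lower numbers for stronger inhibition), compound 1 `Cc1nc(N)c2c(-c3ccccc3)cn([C@@H]3O[C@H](CO)[C@@H](O)[C@H]3O)c2n1` gives only a limit of the assay, > 20000 nM. Compound 2 `Cc1nc(N)c2c(-c3cccs3)cn([C@@H]3O[C@H](CO)[C@@H](O)[C@H]3O)c2n1` likewise gives only a limit, > 20000 nM. Among the compounds with values here, compound 3 `COc1ncnc2c1c(-c1cccs1)cn2[C@@H]1O[C@H](CO)[C@@H](O)[C@H]1O` gives 70 nM in this assay, the only number among the three; how its core differs from that of compound 2 is not broken down here. The change phenyl in place of thiophen-2-yl on an aromatic carbon made a step that the two limits leave unreadable from compound 2 to compound 1, due to the limit of > 20000 nM in this assay, at which 2 of the 3 values shown sit. Compound 4 `COc1ncnc2c1c(-c1ccccc1)cn2[C@@H]1O[C@H](CO)[C@@H](O)[C@H]1O` is not yet measured and arises from compound 3 by the same change, (phenyl in place of thiophen-2-yl on an aromatic carbon). The measured step gives no readable size, so the expectation for compound 4 rests on the value of compound 3, 70 nM. The expected step is estimated as a 2.1-fold higher number from compound 3 to compound 4 (0.33 log units; beyond the scatter) in this assay. Compound 4 is accordingly expected to give about 150 nM, estimated between 40 nM and 800 nM.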

Compound 4, half-maximal inhibitory concentration: > 20000 nM
Compound 4 ended at the assay's limit; the forecaster's own chance of this, stated with the estimate: 10%; middle value at least 130-fold (2.12 log units) away from the limit.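

On the core of compound 3, phenyl in place of thiophen-2-yl made an at least 280-fold higher number from compound 3 to compound 4 (2.45 log units; beyond the scatter) in this assay, so on this core the activity shown is lost with this one change. The same change on the core of compound 2 cannot be read, so the series does not show whether the step carries over from one core to the other with a similar size. The new step gives only a lower bound and not a true size, due to the limit reached by compound 4: the limit of > 20000 nM in this assay, at which 3 of the 4 values shown sit.

The compounds shown leave open how a furan-2-yl or thiophen-3-yl group on the same aromatic carbon would read on the core of compound 3. They also leave open whether an amine or an ethoxy group in place of the methoxy group would keep the potency of compound 3, which gives 70 nM.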